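From 4-methylphenyl to 4-methoxyphenyl in compound 4

The compounds below may be only part of what the source reports. "The series", "measured", "known", "first", "only" and "open" are said of these compounds alone.

In a functional assay on HT-29 cells (Homo sapiens) for antiproliferative activity, read by MTT assay, with a stated time of 72 h (a lower number here means a stronger inhibitor, a higher number a weaker inhibitor), compound 1 `CCCCn1ccnc1-c1cc(OC)c(OC)c(OC)c1` gives > 100000 nM, which is a limit of the assay and not a number. Compound 2 `COc1ccc(-n2ccnc2-c2cc(OC)c(OC)c(OC)c2)cc1[N+](=O)[O-]` gives 600 nM. Compound 3 `COc1cc(-c2nccn2-c2ccc(C)cc2)cc(OC)c1OC` gives 1600 nM, the higher of the two numbers, and its gap to compound 2 lies beyond the usual scatter. Compound 4 `COc1ccc(-n2ccnc2-c2cc(OC)c(OC)c(OC)c2)cc1` has not yet been measured. It differs from compound 3 by methoxy in place of methyl on an aromatic carbon, para to a large group: methoxy in place of methyl on an aromatic carbon. Going by the values given here, the only measured step is an at least 62-fold lower number from compound 1 to compound 3 (1.79 log units; beyond the scatter), which puts 4-methylphenyl in place of butyl on an aromatic nitrogen. That step changes another part of the structure, so its size does not carry over. The closest guide is compound 2 at 600 nM, which also carries a methoxy on that ring. A modest move towards a lower number is therefore expected in this assay. The expected change is a 2.3-fold lower number from compound 3 to compound 4 (0.36 log units; beyond the scatter). For compound 4 the estimated value is 700 nM, with an expected range from 120 nM to 3500 nM.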

Compound 4, half-maximal inhibitory concentration: 13100 nM
Compound 4: the middle estimate sits 19-fold (1.27 log units) below what was measured; the measured number lies above the stated range.
By their numbers in this assay, from the lowest: compound 2; then compound 3; then compound 4. At a limit, above all of these: compound 1.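

Methoxy in place of methyl on an aromatic carbon, para to a large group, is not a neutral swap, and in this assay the change runs against compound 2 as a guide: there is an 8.2-fold higher number from compound 3 to compound 4 (0.91 log units; beyond the scatter). The methoxy alone therefore does not bring the low number of compound 2, since the step that removes only the nitro is a 22-fold higher number from compound 2 to compound 4 (1.34 log units; beyond the scatter). Even so, the 4-methoxyphenyl group still compares favourably with butyl on the aromatic nitrogen, with an at least 7.6-fold lower number from compound 1 to compound 4 (0.88 log units; beyond the scatter), and this step rests on a limit of the assay, not a number: the limit of > 100000 nM in this assay, at which 1 of the 4 values shown sits.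

The compounds shown leave open whether an amine in place of the nitro of compound 2 would keep its number. They also leave open how chlorine or an ethoxy group would read at the position of the methoxy in compound 4.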